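This account rests on a few compounds, and the source may have more. Where it says the series, first, only, none or still open, it means among the compounds named here.

Measured so far in an assay on cells for inhibition of Nicotinamide N-methyltransferase (Homo sapiens), read by fluorescence and coupled enzyme assay, with a stated time of 10 min, in the presence of a further agent that is not named here; on this read-out higher numbers stand for weaker inhibition and lower numbers for stronger inhibition:
compound 1 `Nc1ncnc2c1ncn2[C@@H]1O[C@H](CN(CCCc2ccc3ccccc3c2)CCC[C@H](N)C(=O)O)[C@@H](O)[C@H]1O` gives 33300 nM.
compound 2 `Nc1ncnc2c1ncn2[C@@H]1O[C@H](CN(CCCc2ccc3ccccc3c2)CC[C@H](N)C(=O)O)[C@@H](O)[C@H]1O` gives 4000 nM.
compound 3 `NC(=O)c1cccc(CCCCN(CC[C@H](N)C(=O)O)C[C@H]2O[C@@H](n3cnc4c(N)ncnc43)[C@H](O)[C@@H]2O)c1` gives 840 nM.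

Compound 3 has the lowest number of the three, with steps beyond the scatter to both others. Two single changes connect the set. One is 2-amino-2-carboxyethyl in place of amino(carboxy)methyl on a saturated chain carbon, two bonds along the chain from an amine nitrogen, and on it the number rises, an 8.3-fold higher number from compound 2 to compound 1 (0.92 log units; beyond the scatter). The other is 3-carbamoylbenzyl in place of naphthalen-2-yl on a saturated chain carbon, three bonds along the chain from an amine nitrogen, and on it the number falls, a 4.8-fold lower number from compound 2 to compound 3 (0.68 log units; beyond the scatter).

Compound 4 `NC(=O)c1cccc(CCCCN(CCC[C@H](N)C(=O)O)C[C@H]2O[C@@H](n3cnc4c(N)ncnc43)[C@H](O)[C@@H]2O)c1` is not yet measured in this assay. It differs from compound 3 by 2-amino-2-carboxyethyl in place of amino(carboxy)methyl on a saturated chain carbon, two bonds along the chain from an amine nitrogen. This is the same change as from compound 2 to compound 1, at the same place, now made on the core of compound 3 instead of that of compound 2. On these data alone, the change has been seen once only, so its carry-over to the core of compound 3 is untested.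

The step from compound 3 to compound 4 is expected to resemble the earlier one, estimated as an 8.3-fold higher number from compound 3 to compound 4 (0.92 log units; beyond the scatter). That expectation rests on an 8.3-fold higher number from compound 2 to compound 1 (0.92 log units; beyond the scatter). Starting from compound 3 at 840 nM, compound 4 is estimated at 7000 nM. For compound 4 the number is expected to fall in an estimated range from 2500 nM to 20000 nM.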

Compound 4, inhibition constant: 540 nM
Estimate against measurement, compound 4: 13-fold (1.11 log units) above; measured number below the stated range.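

In this assay, 2-amino-2-carboxyethyl in place of amino(carboxy)methyl does not carry over as a fixed step between the two cores, since on the core of compound 3 it gives a 1.6-fold lower number from compound 3 to compound 4 (0.19 log units; within the scatter): the same change on two cores in this assay, an 8.3-fold higher number (0.92 log units; beyond the scatter) from compound 2 to compound 1 and a 1.6-fold lower number (0.19 log units; within the scatter) from compound 3 to compound 4, 13-fold (1.11 log units) apart, beyond the scatter of two such steps

The paired change, 3-carbamoylbenzyl in place of naphthalen-2-yl, likewise depends on the chain it is paired with, giving a 62-fold lower number from compound 1 to compound 4 (1.79 log units; beyond the scatter): the same change on two cores in this assay, a 4.8-fold lower number (0.68 log units; beyond the scatter) from compound 2 to compound 3 and a 62-fold lower number (1.79 log units; beyond the scatter) from compound 1 to compound 4, 13-fold (1.11 log units) apart, beyond the scatter of two such steps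

The two changes therefore do not add up independently across these four compounds, but this rests on a single set of two cores and does not show how general the dependence is or what lies behind it.

Open, on these data alone, is whether 4-amino-4-carboxybutyl, a longer chain by the same difference, would stay level with compound 3 and compound 4 on the 3-carbamoylbenzyl core. Also open, as far as these compounds go, is whether a nitrile in place of the carbamoyl group of 3-carbamoylbenzyl would show the same dependence on chain length.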